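The compounds below may be only part of what the source reports. "The series", "measured", "known", "first", "only" and "open" are said of these compounds alone.

Compound 1 `COc1cccc(/C=N/c2c(C)n(C)n(-c3ccccc3)c2=O)c1` is the starting point of this short series. For the measured compounds named here, in a functional assay on HCT-116 cells (Homo sapiens) for cytotoxicity, read by MTT assay, with a stated time of 72 h (a higher number here means a weaker inhibitor, a lower number a stronger inhibitor), compound 1 gives 933000000 nM, the highest of the three numbers measured so far. Compound 2 `COc1ccc(/C=N/c2c(C)n(C)n(-c3ccccc3)c2=O)cc1OC` gives 575000000 nM, and compound 3 `COc1ccccc1/C=N/c1c(C)n(C)n(-c2ccccc2)c1=O` gives 324000000 nM. The move from compound 1 to compound 2 adds a methoxy group and shows a 1.6-fold lower number from compound 1 to compound 2 (0.21 log units; within the scatter); the move to compound 3 shifts the methoxy group on the ring and shows a 2.9-fold lower number from compound 1 to compound 3 (0.46 log units; beyond the scatter).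

Compound 4 `COc1cccc(/C=N/c2c(C)n(C)n(-c3ccccc3)c2=O)c1O` changes compound 1 by hydroxy in place of hydrogen on an aromatic carbon. The closest measured step is the addition of a methoxy group in compound 2, which was a 1.6-fold lower number from compound 1 to compound 2 (0.21 log units; within the scatter), so only a small shift is expected. Compound 4 is therefore estimated at 800000000 nM, with a likely range from 300000000 nM to 2000000000 nM, meaning an expected step of a 1.2-fold lower number from compound 1 to compound 4 (0.07 log units; within the scatter).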

Compound 4, half-maximal inhibitory concentration: 89100000 nM
The estimate for compound 4 lay 9.0-fold (0.95 log units) above the measured number, and the stated range ends above it.
By their numbers in this assay, from the lowest: compound 4; then compounds 3, 2 and 1 (each within the scatter of the next, the first and the last beyond it).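

Hydroxy in place of hydrogen on this aromatic carbon, ortho to a large group and ortho to a methoxy group, gives a 10-fold lower number from compound 1 to compound 4 (1.02 log units; beyond the scatter), the largest step so far in this assay. An added methoxy group gave only a 1.6-fold lower number from compound 1 to compound 2 (0.21 log units; within the scatter), so the ring does not respond alike to every added group. Nothing available here explains the size of the hydroxy step.

From the compounds shown here alone, it remains open whether an amine or a methoxy group on this same carbon would give a similar step. Going by these compounds, it is also open whether hydroxy would have the same effect without the existing methoxy group.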